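The source may report more compounds than this note shows. Statements on the series, on what has been measured and on what is new or still open speak of the compounds shown alone.

Compound 2 `Cc1cccc(Cc2cnc(CCc3ccc(-c4ccccc4C(=O)O)cc3)[nH]2)c1` is a carboxylic-acid-bearing biaryl linked through a two-carbon chain to a five-membered aromatic ring with two nitrogens, which carries a 3-methylbenzyl group. In an in vitro functional assay on cells for agonist activity at Bombesin receptor subtype-3 (Mus musculus), read by luminescence and calcium flux (on this read-out lower numbers stand for an effect already at smaller amounts and higher numbers for an effect only at larger amounts of compound), compound 2 gives 75 nM. Among the three measured compounds this is the second highest number: compound 1 `CCCCc1cnc(C(CCCO)Cc2ccc(-c3ccccc3C(=O)O)cc2)[nH]1` gives 238 nM, while compound 3 `O=C(O)c1ccccc1-c1ccc(CCc2ncc(Cc3cccc(F)c3F)[nH]2)cc1` gives 8 nM. Among the measured compounds shown here, the one single-point step recorded is a 9.4-fold lower number from compound 2 to compound 3 (0.97 log units; beyond the scatter), where 2,3-difluorophenyl replaces 3-methylphenyl on a saturated chain carbon bound to an aromatic carbon.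

Compound 4 `O=C(O)c1ccccc1-c1ccc(CCc2ncc(C3CCCCC3)[nH]2)cc1` differs from compound 2 by cyclohexyl in place of 3-methylbenzyl on an aromatic carbon. For the measured compounds named here, this change removes the aromatic ring together with its chain carbon and puts a cyclohexyl ring directly on the aromatic carbon; no measured step does the same. The step from compound 2 to compound 3 shows that this position is sensitive, but it swaps one aromatic ring for another and gives no direction for a non-aromatic ring. A weakening of modest size, a 2.7-fold higher number from compound 2 to compound 4 (0.43 log units; beyond the scatter), is therefore expected, with wide uncertainty. Compound 4 is estimated at 200 nM, within 50 nM to 800 nM.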

Compound 4, half-maximal effective concentration: 14.7 nM
Beside the measured number, compound 4's estimate is 14-fold (1.13 log units) above it; the whole stated range lies above it.
By their numbers in this assay, from the lowest: compounds 3 and 4 (each within the scatter of the next); then compound 2; then compound 1.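

Putting cyclohexyl in place of 3-methylbenzyl on this aromatic carbon gives a 5.1-fold lower number from compound 2 to compound 4 (0.71 log units; beyond the scatter) in this assay, so a low number here does not require an aromatic ring or a chain carbon between the two rings. The change to cyclohexyl from the other benzyl group gives a 1.8-fold higher number from compound 3 to compound 4 (0.26 log units; within the scatter) and leaves cyclohexyl and 2,3-difluorobenzyl indistinguishable, which means that two quite different groups both fit this position in this read-out. No measurement on hand explains this result.

The step from 3-methylbenzyl to cyclohexyl changes two things at once, the ring type and the loss of the chain carbon, and the compounds shown cannot separate them. A cyclohexylmethyl group would keep the chain carbon with the non-aromatic ring, while a phenyl group would keep the aromatic ring without it.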